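The source may report more compounds than this note shows. Statements on the series, on what has been measured and on what is new or still open speak of the compounds shown alone.

Three compounds share a common core and differ only in the aryl group attached through the oxygen. Compound 1 `Cc1ccccc1Oc1ccc(N2C[C@@H](C(F)(F)F)C[C@H]2CC(=O)O)cc1` gives 330 nM in a functional assay on cells for agonist activity at Free fatty acid receptor 1 (Mus musculus), read by FLIPR and calcium flux, with a stated time of 100 s; on this read-out higher numbers stand for an effect only at larger amounts of compound and lower numbers for an effect already at smaller amounts. Compound 2 `COc1ccc(Oc2ccc(N3C[C@@H](C(F)(F)F)C[C@H]3CC(=O)O)cc2)c(C)c1` gives 170 nM in this assay, and compound 3 `Cc1c(Cl)cccc1Oc1ccc(N2C[C@@H](C(F)(F)F)C[C@H]2CC(=O)O)cc1` gives 430 nM. Compound 3 carries the highest of the three numbers: its gap to compound 1, a 1.3-fold higher number from compound 1 to compound 3 (0.11 log units; within the scatter), is within the scatter, while its gap to compound 2, a 2.5-fold higher number from compound 2 to compound 3 (0.40 log units; beyond the scatter), is beyond it.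

Compound 4 `Cc1cccc(C)c1Oc1ccc(N2C[C@@H](C(F)(F)F)C[C@H]2CC(=O)O)cc1` differs from compound 3 by 2,6-dimethylphenyl in place of 3-chloro-2-methylphenyl on an oxygen on an aromatic ring. Going by the values given here, the steps that bear on this are the small substituent swaps on that aryl group: a 1.3-fold higher number from compound 1 to compound 3 (0.11 log units; within the scatter) and a 1.9-fold lower number from compound 1 to compound 2 (0.29 log units; within the scatter) both stay within the scatter, and only a 2.5-fold higher number from compound 2 to compound 3 (0.40 log units; beyond the scatter) reaches a modest size. Exchanging chloro for a second methyl on the same ring is therefore expected to move this assay by no more than the scatter, in either direction. For compound 4 the estimated step is a 1.3-fold lower number from compound 3 to compound 4 (0.13 log units; within the scatter). Compound 4 is expected to show about 320 nM, with a range from 130 nM to 800 nM.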

Compound 4, half-maximal effective concentration: 270 nM
The estimate for compound 4 lay 1.2-fold (0.07 log units) above the measured number; measured number inside the range.
By their numbers in this assay, from the lowest: compounds 2, 4, 1 and 3 (each within the scatter of the next, the first and the last beyond it).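

A second methyl on the aryl group attached through the oxygen (a 1.2-fold lower number from compound 1 to compound 4 (0.09 log units; within the scatter)) leaves the number within the scatter, and so does 2,6-dimethylphenyl in place of 3-chloro-2-methylphenyl (a 1.6-fold lower number from compound 3 to compound 4 (0.20 log units; within the scatter)). The step from the 4-methoxy-2-methylphenyl group (a 1.6-fold higher number from compound 2 to compound 4 (0.20 log units; within the scatter)) is also within the scatter, so 2,6-dimethylphenyl, unlike 3-chloro-2-methylphenyl, is not set apart from that group by more than the usual variation between repeats. Nothing measured here accounts for how closely these groups read.

The aryl groups shown carry only methyl, chloro and methoxy, so it remains open how an amine, a carboxylic acid or a longer chain on this ring would read in this assay at all. The shared core is the same throughout, so these compounds say nothing about changes made there.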